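The source may report more compounds than this note shows. Statements on the series, on what has been measured and on what is new or still open speak of the compounds shown alone.

Measured compounds in the series:

compound 1 `CC(=O)Nc1cc(-c2ccc(OC[C@@](C)(N)CC(C)C)c(F)c2)ccn1` with 0.24 nM
compound 2 `COC(=O)Nc1cc(-c2ccc(OC[C@@](C)(N)CC(C)C)nc2)ccn1` with 4.9 nM
compound 3 `COC(=O)Nc1cc(-c2cc(C)c(OC[C@@](C)(N)CC(C)C)cn2)ccn1` with 1.4 nM

All three were run in an assay on brain (strain C57BL6) for displacement of a labelled ligand from AP2-associated protein kinase 1 (Mus musculus), read by scintillation counting, with a stated time of 1 h; on this read-out lower numbers stand for stronger inhibition and higher numbers for weaker inhibition. Among the three, compound 2 has the highest number; its nearest neighbour is compound 3, whose number is lower by a margin beyond the scatter, and compound 1 lies furthest away, lower still. Going by the values given here, compound 3 and compound 1 each differ from compound 2 in more than one place, so no single step between measured compounds is available.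

Compound 4 `COC(=O)Nc1cc(-c2cnc(OC[C@@](C)(N)CC(C)C)c(OC)c2)ccn1` has not yet been measured. It is derived from compound 2 by a single change: methoxy in place of hydrogen on an aromatic carbon. Among the compounds with values here, no measured pair shows this exact change. Since the two compounds with a lower number than compound 2 are compound 3 with 1.4 nM and compound 1 with 0.24 nM, a modest shift toward a lower number is expected, though nothing beyond the scatter is ruled out. The expected step is a 2.5-fold lower number from compound 2 to compound 4 (0.39 log units; beyond the scatter). Compound 4 is estimated at 2 nM, within a range from 0.6 nM to 6.5 nM.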

Compound 4, inhibition constant: 2.5 nM
Compound 4: middle estimate off by 1.3-fold (0.10 log units), on the low side; the measured number falls inside the stated range.
By their numbers in this assay, from the lowest: compound 1; then compounds 3, 4 and 2 (each within the scatter of the next, the first and the last beyond it).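

In this assay the step is a 2.0-fold lower number from compound 2 to compound 4 (0.29 log units; within the scatter) for methoxy in place of hydrogen on an aromatic carbon, ortho to the (2-amino-2,4-dimethylpentyl)oxy group and two atoms from the ring nitrogen. Going by these compounds alone, this is the first single-place comparison, and it shows that this position can carry methoxy with no change that can be told from the scatter. No supporting data bear on this result, so it stands as an observation on one pair only.

On these data alone, whether an amine, a carboxylic acid or a longer alkoxy chain on the same aromatic carbon would move the number beyond the scatter remains open. Compound 1 and compound 3 each differ from compound 4 in more than one place, so no single step yet accounts for where their numbers lie.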